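Three values and the expected place of compound 4

The compounds below may be only part of what the source reports. "The series", "measured", "known", "first", "only" and "open" are said of these compounds alone.

In a physicochemical assay for lipophilicity, read by HPLC, measured as chromatographic lipophilicity, at pH 7.4 (on this read-out higher numbers stand for higher lipophilicity and lower numbers for lower lipophilicity), compound 1 (`O=C(C1CCOC1)N1N=CCC1c1ccccc1`) gives 3, compound 2 (`CC(C)C(=O)N1N=CCC1c1ccccc1`) gives 4.4 and compound 3 (`O=C(c1cccnc1)N1N=CCC1c1ccccc1`) gives 2.7. The two steps reaching compound 3 differ sharply: a number 0.30 log units lower from compound 1 to compound 3 (within the scatter), whereas a number 1.70 log units lower from compound 2 to compound 3 (beyond the scatter). Compound 3 thus stands level with compound 1 and well apart from compound 2.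

Compound 4 (`CC(C)(CO)C(=O)N1N=CCC1c1ccccc1`) is still unmeasured. Its change from compound 3 is 1-(hydroxymethyl)-1-methylethyl in place of pyridin-3-yl on a carbonyl carbon, with 1-(hydroxymethyl)-1-methylethyl in place of pyridin-3-yl on a carbonyl carbon. Going by the values given here, no measured step makes this exact exchange, so the evidence is indirect. The entering group has no ring, as isopropyl has none, and it holds an oxygen, as oxolan-3-yl does. The step linking those two groups is large: a number 1.40 log units higher from compound 1 to compound 2 (beyond the scatter). The large step to pyridin-3-yl from isopropyl, already given, bears on the change too. Compound 4 shares features with both compound 1 and compound 2, so a value between theirs, closer to compound 1, is expected. The expected step in this assay is a number 0.50 log units higher from compound 3 to compound 4 (beyond the scatter), upward and well short of the large steps. Compound 4 is estimated at 3.2, with an expected range from 2.6 to 3.9.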

Compound 4, distribution coefficient: 3.4
Estimate against measurement, compound 4: 0.20 log units below; measured number inside the range.
By their numbers in this assay, from the lowest: compounds 3 and 1 (each within the scatter of the next); then compound 4; then compound 2.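

Working notes on the acyl position, on a carbonyl carbon whose other neighbours are amide-type nitrogen in a ring. In this assay, going by these compounds alone, the single exchange of hydroxymethyl for hydrogen on the isopropyl group gives a number 1.00 log units lower from compound 2 to compound 4 (beyond the scatter) and so shows that this position responds to a small change on a ring-free group, not only to an exchange of the whole group. The ring-free group with its hydroxyl does not fall level with the ring-bearing groups: the steps read a number 0.70 log units higher from compound 3 to compound 4 (beyond the scatter) and a number 0.40 log units higher from compound 1 to compound 4 (beyond the scatter) and both lie beyond the scatter, which places compound 4 on its own level, with compound 2 higher still. Across these four compounds the two ring-free groups give the higher numbers, and none of the compounds shown goes against that split, while no measurement shown gives a cause for any of these steps.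

Open, on these data alone, is whether a methoxymethyl, an aminomethyl or a carboxylic acid in place of the hydroxymethyl would give a step of similar size. Also open, as far as these compounds go, is whether a longer chain carrying the hydroxyl would keep compound 4's level, and whether the same hydroxymethyl exchange would give a comparable step on a ring-bearing group.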